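A few compounds are considered here, and "the series" means these few. Any claim that something is new, unique, unknown or untested is made for them only; others in the source may bear on it.

Working notes on the series around the shared core of compound 1 `Cc1nc(-c2ccccc2)c(C(=O)N2CCN(c3ccc(C(F)(F)F)cc3)CC2)o1`. In a functional assay on HL-60 cells (Homo sapiens) for inhibition, read by MTT assay, with a stated time of 72 h (on this read-out lower numbers stand for stronger inhibition and higher numbers for weaker inhibition), compound 1 gives > 1000 nM, which is a limit of the assay and not a number. Compound 1 sits at the limit of > 1000 nM in this assay, at which 1 of the 2 values shown sits. Compound 2 `CCc1nc(-c2ccccc2Cl)c(C(=O)N2CCN(c3cccc(Cl)c3)CC2)o1` gives 98.9 nM in this assay. Compound 3 `Cc1nc(-c2ccccc2)c(C(=O)N2CCN(c3ccccc3)CC2)o1` remains to be measured in this assay. It differs from compound 1 in one place: hydrogen in place of trifluoromethyl on an aromatic carbon. Among the measured compounds shown here, no step between measured compounds is at hand for this change; the step that the limit leaves unreadable from compound 1 to compound 3 is expected to be none beyond the scatter, with the result most likely again a limit. Compound 3 is thus expected to give 3000 nM, within 800 nM to 20000 nM.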

Compound 3, half-maximal inhibitory concentration: 39.1 nM
For compound 3 the middle estimate is 77-fold (1.88 log units) above the measured one; measured number outside the range, below it.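

At this place, para to a large group, the substituent matters in this assay: 4-(trifluoromethyl)phenyl to phenyl gives an at least 25-fold lower number from compound 1 to compound 3 (1.40 log units; beyond the scatter). The value of compound 1 is a limit of the assay and not a number, so the full size of this step stays unread: the limit of > 1000 nM in this assay, at which 1 of the 3 values shown sits.

The compounds shown leave open whether a methoxy group, an amine or a single fluorine at this place would track hydrogen or trifluoromethyl. Compound 2 differs from compound 3 in more than one place, so it gives no reading of this position.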